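Expected cytotoxicity after swapping dimethylphenoxy for chlorophenoxy

The compounds below may be only part of what the source reports. "The series", "measured", "known", "first", "only" and "open" are said of these compounds alone.

Compound 3 `Cc1cccc(C)c1Oc1nc(Nc2ccc(C#N)cc2)nc2ccccc12` gives the lowest number among the measured compounds: in an ADME assay on MT4 cells (Homo sapiens) for cytotoxicity, read by MTT assay, with a stated time of 4 days (on this read-out lower numbers stand for higher toxicity in this test and higher numbers for lower toxicity in this test), compound 3 shows 35000 nM. Compound 1 `Cc1cccc(Oc2nc(Nc3ccc(C#N)cc3)nc3ccccc23)c1` gives 355000 nM, and against it stands a 10-fold lower number from compound 1 to compound 3 (1.01 log units; beyond the scatter). Compound 2 `COc1cc(C#N)ccc1Oc1nc(Nc2ccc(C#N)cc2)nc2ccccc12` reaches only a limit of the assay, >= 140000 nM. Even so, an at least 4.0-fold lower number from compound 2 to compound 3 (0.60 log units; beyond the scatter) remains readable, since the limit of >= 140000 nM in this assay, at which 1 of the 3 values shown sits, still leaves that gap open. Compound 4 `N#Cc1ccc(Nc2nc(Oc3ccc(Cl)cc3)c3ccccc3n2)cc1` differs from compound 3 by 4-chlorophenyl in place of 2,6-dimethylphenyl on an oxygen on an aromatic ring. Both measured steps into compound 3 lowered the number, so moving away from 2,6-dimethylphenyl toward a single small substituent is expected to raise it again, by roughly a 4.3-fold higher number from compound 3 to compound 4 (0.63 log units; beyond the scatter). Compound 4 is therefore estimated at 150000 nM, with a range from 40000 nM to 400000 nM.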

Compound 4, half-maximal cytotoxic concentration: 198000 nM
For compound 4 the middle estimate is 1.3-fold (0.12 log units) below the measured one; the measured number falls inside the stated range.
By their numbers in this assay, from the lowest: compound 3; then compounds 4 and 1 (each within the scatter of the next).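

Replacing 2,6-dimethylphenyl on the oxygen with 4-chlorophenyl gives a 5.7-fold higher number from compound 3 to compound 4 (0.75 log units; beyond the scatter), so a chlorine-bearing ring at this position also stays clear of the low number of compound 3. Against 3-methylphenyl there is a 1.8-fold lower number from compound 1 to compound 4 (0.25 log units; within the scatter), so 4-chlorophenyl and 3-methylphenyl are not separated here. Compound 2 stands at a limit, and its step to compound 4 cannot be read: the limit of >= 140000 nM in this assay, at which 1 of the 4 values shown sits.

Open, on these data alone, is whether 2,6-dichlorophenyl would lower the number as 2,6-dimethylphenyl does. Also open, as far as these compounds go, is how a ring carrying an amine or a carboxylic acid would read.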